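Swapping a Fluorinated Aryl Group on a Dichloro Core

The compounds below may be only part of what the source reports. "The series", "measured", "known", "first", "only" and "open" are said of these compounds alone.

For the measured compounds named here, compound 1 `Cc1cc(F)ccc1-c1cc(Cl)cc(Cl)c1/C=C/[C@@H]1C[C@@H](O)CC(=O)O1` and compound 2 `Cc1cc(-c2cccc(Cl)c2/C=C/[C@@H]2C[C@@H](O)CC(=O)O2)ccc1F` share a core but differ in more than one place, so no single step joins them. Going by the values given here, in an assay for inhibition of 3-hydroxy-3-methylglutaryl-coenzyme A reductase (Rattus norvegicus) (a higher number here means a weaker inhibitor, a lower number a stronger inhibitor), compound 1 gives 36 nM, the larger of the two numbers so far, though the gap to compound 2, which gives 30 nM, lies within the scatter. Compound 3 `O=C1C[C@H](O)C[C@@H](/C=C/c2c(Cl)cc(Cl)cc2-c2cccc(F)c2)O1` is not yet measured. It differs from compound 1 in one place: 3-fluorophenyl in place of 4-fluoro-2-methylphenyl on an aromatic carbon. With only two measured compounds, both close together, there is no shown step against which this change can be weighed. The step of a 1.3-fold higher number from compound 1 to compound 3 (0.10 log units; within the scatter) in this assay is expected to be small, tending toward a slightly higher number, and may well remain within the scatter. Compound 3 is therefore estimated at 45 nM, with a range from 18 nM to 110 nM.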

Compound 3, half-maximal inhibitory concentration: 70 nM
Compound 3: the middle estimate sits 1.6-fold (0.19 log units) below what was measured; low and high end bracket the measured number.
By their numbers in this assay, from the lowest: compounds 2, 1 and 3 (each within the scatter of the next, the first and the last beyond it).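

In this assay, for the compounds shown here, the exchange of 4-fluoro-2-methylphenyl for 3-fluorophenyl on this aromatic carbon gives a 1.9-fold higher number from compound 1 to compound 3 (0.29 log units; within the scatter), the first step that can be read at this position. It shows that this aryl group can lose its methyl and carry its fluorine at a different ring position while the number stays within the scatter of compound 1, so this one change gives no firm difference in this assay. Nothing measured here speaks to the reason for the size of this step.

Going by these compounds alone, the single step alters the methyl and the fluorine together, so the share of each remains open. Also open, on these data alone, is how this assay responds when this aromatic carbon bears a phenyl ring carrying an amine or a carboxylic acid.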